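Sulfonamide series: lipophilicity after an N-substituent exchange

The source may hold more compounds than are shown below. What is called first, only, known or untested is meant among the compounds shown, and "the series" means these compounds.

Measured so far:
compound 1, `CCc1ccc(N(C2CCC2)S(=O)(=O)c2ccc3c(c2)C(=O)CC(C2CCOCC2)O3)cc1`, 3.78
compound 2, `CC(C)CN(c1ccc(C(C)(C)C)cc1)S(=O)(=O)c1ccc2c(c1)C(=O)CC(C1CCOCC1)O2`, 4.97
compound 3, `CCc1ccc(N(CC(C)C)S(=O)(=O)c2ccc3c(c2)C(=O)C[C@@H](C2CCOCC2)O3)cc1`, 4.2

In a physicochemical assay for lipophilicity, at pH 7.4 (a higher number here means a more lipophilic compound, a lower number a more polar compound), compound 2 stands highest of the three numbers. Compound 3 is nearest to it, and its value is lower than that of compound 2 by more than the scatter; compound 1 is furthest from it, lower still and likewise beyond the scatter. Among the compounds with values here, no two measured compounds differ in only one place, so no single step between them can be separated out.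

Compound 4, `CC(C)CN(C1CCc2ccc(F)cc21)S(=O)(=O)c1ccc2c(c1)C(=O)CC(C1CCOCC1)O2`, is not yet measured in this assay. It differs from compound 2 in this way: 6-fluoro-2,3-dihydro-1H-inden-1-yl in place of 4-(tert-butyl)phenyl on a sulfonamide nitrogen. The group that leaves is a benzene ring carrying a tert-butyl group; the group that enters carries one fluorine and a fused five-membered non-aromatic ring. Both have the same heavy-atom count and neither brings donors or acceptors.

Compound 4 is expected to come out lower than compound 2 in this assay, by a step of a number 0.47 log units lower from compound 2 to compound 4 (beyond the scatter), which lies beyond the scatter. The estimate for compound 4 is 4.5, with a range from 4 to 5.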

Compound 4, distribution coefficient: 4.03
Compound 4: middle estimate off by 0.47 log units, on the high side; the measured number falls inside the stated range.
By their numbers in this assay, from the lowest: compounds 1, 4 and 3 (each within the scatter of the next, the first and the last beyond it); then compound 2.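

In this assay, within the data shown here, the exchange of 4-(tert-butyl)phenyl for 6-fluoro-2,3-dihydro-1H-inden-1-yl on a sulfonamide nitrogen gives the first single-place step, a number 0.94 log units lower from compound 2 to compound 4 (beyond the scatter). The heavy-atom count stays the same and neither group has hydrogen-bond donors or acceptors, so a step of this size at this position arises without any change in those counts. Nothing available accounts for the size of the step.

A single pair cannot separate the contributions of the fluorine, the five-membered non-aromatic ring and the tert-butyl group to this step. As far as these compounds go, how an unfluorinated 2,3-dihydro-1H-inden-1-yl, or a group carrying an amine or a carboxylic acid, would read on this nitrogen in this assay remains open.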